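The compounds below may be only part of what the source reports. "The series", "measured", "known", "first", "only" and "open" are said of these compounds alone.

In an ADME assay on microsomes from liver (Rattus norvegicus) for metabolic stability (on this read-out higher numbers stand for a longer-lived compound and lower numbers for a shorter-lived compound), compound 1 (`CC(C)C(Nc1nnc[nH]1)c1ccc(-c2ccc3cccc(F)c3c2)[nH]c1=O`) gives 1.29 h. Compound 2 (`CCn1ncc2c(F)cc(-c3ccc(C(CC)(CC)c4nnc[nH]4)c(=O)[nH]3)cc21`) reads > 3 h, which is a limit of the assay and not a number. Its true position is therefore open on the upper side, and that is the limit of > 3 h in this assay, at which 1 of the 2 values shown sits. Compound 3 (`CCn1ncc2c(F)cc(-c3ccc(C(CC)(CC)c4nnc(C)[nH]4)c(=O)[nH]3)cc21`) departs from compound 2 by one change, methyl in place of hydrogen on an aromatic carbon, taking the 4H-1,2,4-triazol-3-yl to 5-methyl-4H-1,2,4-triazol-3-yl. Going by the values given here, no measured pair isolates this change, so its size in this assay cannot be read from the data. The working expectation is no shift beyond the scatter, in either direction. On that basis the expected step is a number no higher from compound 2 to compound 3 (the limit leaves the size open). A reading at the same limit remains quite possible. For compound 3 the estimated half-life is 3 h, with an expected range of 1.5 h to 6 h.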

Compound 3, half-life: > 3 h
Compound 3 ended at the assay's limit (the forecaster's own chance of this, stated with the estimate: 55%); the middle value sits exactly at the limit.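

Compound 2 and compound 3 both read at a limit of the assay, not a number, so no step can be read between them: the limit of > 3 h in this assay, at which 2 of the 3 values shown sit.

Still open, as far as these compounds go, is how far compound 2 and compound 3 each lie past that limit, and so what size, if any, methyl in place of hydrogen on the triazole has in this assay.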